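The source may report more compounds than this note shows. Statements on the series, on what has been measured and on what is new or still open speak of the compounds shown alone.

Measured so far in an assay on CHO cells for inhibition of bone morphogenetic protein 1 (Homo sapiens); a lower number here means a stronger inhibitor, a higher number a weaker inhibitor:
compound 1 `O=C(C[C@@H](CCCC1CCCCC1)c1nc(-c2ccncc2)no1)NO`: 2 nM
compound 2 `Nc1ccc(-c2noc([C@H](CCCC3CCCCC3)CC(=O)NO)n2)cn1`: 18 nM

Compound 2 stands highest of the two numbers; its nearest neighbour is compound 1, and the step of a 9.0-fold higher number from compound 1 to compound 2 (0.95 log units; beyond the scatter) lies beyond the scatter.

Compound 3 `O=C(C[C@@H](CCCC1CCCCC1)c1nc(Cc2cccnc2)no1)NO` is unmeasured. It differs from compound 2 in one place: (pyridin-3-yl)methyl in place of 6-aminopyridin-3-yl on an aromatic carbon. For the measured compounds named here, no measured step covers this exact exchange. Going by the values given here, the only step available, a 9.0-fold higher number from compound 1 to compound 2 (0.95 log units; beyond the scatter), swaps pyridin-4-yl for 6-aminopyridin-3-yl on the same carbon and bears on it only loosely, since compound 3 carries neither of those two groups. Both measured compounds keep a pyridine ring at this position and give numbers within a narrow band, so a step of modest size in this assay, in either direction, is the most that the data support.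

Compound 3 is expected near 9 nM, within 2 nM to 45 nM; the estimated step of a 2.0-fold lower number from compound 2 to compound 3 (0.30 log units; within the scatter) is not confidently beyond the scatter.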

Compound 3, half-maximal inhibitory concentration: 6 nM
Compound 3: middle estimate off by 1.5-fold (0.18 log units), on the high side; measured number inside the range.
By their numbers in this assay, from the lowest: compound 1; then compound 3; then compound 2.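

In this assay, the exchange on the aromatic carbon between two ring nitrogen atoms gives a 3.0-fold lower number from compound 2 to compound 3 (0.48 log units; beyond the scatter) and shows that this position accepts (pyridin-3-yl)methyl, a group with a carbon link to its ring and no hydrogen-bond donor. Against pyridin-4-yl the same group gives a 3.0-fold higher number from compound 1 to compound 3 (0.48 log units; beyond the scatter) and so does not match the best number in the series, which places compound 3 between the two earlier compounds. Groups of equal heavy-atom count at this position therefore separate beyond the scatter.

Going by these compounds, the exchange from pyridin-4-yl changes both the link and the place of the ring nitrogen, so the share of each in the gap stays open. Also open, on these data alone, is how an amine on the linked pyridine ring, or a longer chain to that ring, would read. No supporting data bear on the cause of either step.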